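Diiodosalicylaldehyde hydrazones: cytotoxicity notes, compound 4

The source may report more compounds than this note shows. Statements on the series, on what has been measured and on what is new or still open speak of the compounds shown alone.

Measured so far:
compound 1 `COc1ccc(C(=O)N/N=C/c2cc(I)cc(I)c2O)cc1` — 45200 nM
compound 2 `CC(C)(C)c1ccc(C(=O)N/N=C/c2cc(I)cc(I)c2O)cc1` — 41600 nM
compound 3 `O=C(N/N=C/c1cc(I)c(O)c(I)c1)c1ccc(O)cc1` — 110000 nM

The three hydrazones share the same core and differ only in the substituent on the benzoyl ring. In a functional assay on HepG2 cells (Homo sapiens) for cytotoxicity, with a stated time of 24 h (on this read-out lower numbers stand for stronger inhibition and higher numbers for weaker inhibition), compound 3 gives the highest number of the three; compound 1 and compound 2 both sit beyond the scatter below it. Compound 4 `O=C(N/N=C/c1cc(I)c(O)c(I)c1)c1ccc([N+](=O)[O-])cc1` is not yet measured; it arises from compound 3 by nitro in place of hydroxy on an aromatic carbon.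

For the measured compounds named here, the only single-point step available in this assay is a 1.1-fold lower number from compound 1 to compound 2 (0.04 log units; within the scatter), so exchanging one substituent for another at the same position did not move the number there. That step does not involve hydroxy or nitro, so its bearing on the present change is indirect. Going by the values given here, the values of compound 1 and compound 3 show that hydroxy stands at a higher number than methoxy, beyond the scatter, but no direct step is given.

On this thin basis a modest step toward a lower number is expected for compound 4 in this assay, a 2.0-fold lower number from compound 3 to compound 4 (0.30 log units; within the scatter), with wide uncertainty. Compound 4 is therefore estimated at 55000 nM, within a range from 25000 nM to 130000 nM.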

Compound 4, half-maximal inhibitory concentration: 92100 nM
For compound 4 the middle estimate is 1.7-fold (0.22 log units) below the measured one, and the stated range covers the measured number.
By their numbers in this assay, from the lowest: compounds 2 and 1 (each within the scatter of the next); then compounds 4 and 3 (each within the scatter of the next).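

In this assay the exchange at this position gives a 1.2-fold lower number from compound 3 to compound 4 (0.08 log units; within the scatter), so on the core of compound 3 the number stays within the scatter for this pair. For the compounds shown here, this is the first direct reading at this position on that core, and it spans a clear difference in the group: para to a large group, 1 heavy atom and 1 hydrogen-bond donor give way to 3 heavy atoms and 0 hydrogen-bond donors, with no matching move in the read-out. No measurement on hand offers an explanation for this flat step.

Going by these compounds alone, compounds 3 and 4 differ from compounds 1 and 2 in more than one place, so it remains open whether the same exchange would behave alike on the core of compound 1, and the one step among compounds 1 and 2 cannot settle that. Also open, from the compounds shown here alone, is whether this position stays as flat with an amine, a carboxylic acid or a longer chain in place of hydroxy, since a single pair gives no trend.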